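Methoxy in place of chloro: expectation for compound 4

The compounds below may be only part of what the source reports. "The series", "measured", "known", "first", "only" and "open" are said of these compounds alone.

Compound 1 `Clc1ccc(-c2noc(-c3cc4ccccc4[nH]3)n2)cc1`: in a functional assay on MIA PaCa-2 cells (Homo sapiens) for antiproliferative activity, read by WST assay, with a stated time of 72 h (a higher number here means a weaker inhibitor, a lower number a stronger inhibitor), compound 1 gives 19200 nM.
Compound 2 `Fc1ccc2[nH]c(-c3nc(-c4ccc(Cl)cc4)no3)cc2c1`: in this assay compound 2 gives only a limit of the assay, > 50000 nM.
Compound 3 `Clc1ccc(-c2noc(-c3cc4cc(Cl)ccc4[nH]3)n2)cc1`: in this assay compound 3 likewise reaches only a limit of the assay, > 50000 nM.

Compound 2 stands at the limit of > 50000 nM in this assay, at which 2 of the 3 values shown sit, and has no number of its own. The step from compound 1 to compound 2 was an at least 2.6-fold higher number from compound 1 to compound 2 (0.41 log units; beyond the scatter), and that from compound 1 to compound 3 was an at least 2.6-fold higher number from compound 1 to compound 3 (0.41 log units; beyond the scatter). Between compound 2 and compound 3 the step is a step that the two limits leave unreadable from compound 2 to compound 3. Compound 4 `COc1ccc(-c2noc(-c3cc4cc(F)ccc4[nH]3)n2)cc1` differs from compound 2 by methoxy in place of chloro on an aromatic carbon. Among the measured compounds shown here, none of the measured steps varies that group; all three change the other ring, so no measured step bears directly on this change. Because compound 2 sits at the limit of > 50000 nM in this assay, at which 2 of the 3 values shown sit, compound 4 is expected to remain weak. The step from compound 2 to compound 4 is estimated as a number no higher from compound 2 to compound 4 (the limit leaves the size open). For compound 4 the expected value in this assay is 50000 nM, within 15000 nM to 150000 nM.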

Compound 4, half-maximal inhibitory concentration: 10300 nM
Compound 4: the middle estimate sits 4.9-fold (0.69 log units) above what was measured; the whole stated range lies above it.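

In this assay, among the compounds shown here, the group para to a large group proves to matter: methoxy in place of chloro on an aromatic carbon gives an at least 4.8-fold lower number from compound 2 to compound 4 (0.68 log units; beyond the scatter), the first change at this place. With fluoro held on the other ring, compound 4 returns a true number, so weakness at that ring is not fixed. The full size of the step stays open, since compound 2 is only a limit of the assay: the limit of > 50000 nM in this assay, at which 2 of the 4 values shown sit.

As far as these compounds go, whether methoxy has the same effect on the cores of compound 1 and compound 3 remains open. So does how an amine or a longer chain would read at this place.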